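Cytotoxicity notes on the step from compound 3 to compound 4

The compounds below may be only part of what the source reports. "The series", "measured", "known", "first", "only" and "open" are said of these compounds alone.

Compound 1 `Cc1ccc2nc(Cl)c(/C=C3\C(=O)N(c4c(Cl)cccc4Cl)c4ccccc43)cc2c1C`, compound 2 `O=C1/C(=C\c2cccc(Oc3ccccc3)c2)c2ccccc2N1c1c(Cl)cccc1Cl` and compound 3 `CN(C)c1ccc(/C=C2\C(=O)N(c3c(Cl)cccc3Cl)c3ccccc32)cc1` share one core and differ only in the group on the double-bonded chain carbon. In a functional assay on B16-F10 cells (Homo sapiens) for cytotoxicity against B16-F10 (Mus musculus), read by MTT assay, with a stated time of 72 h (a lower number here means that less compound is needed, a higher number that more compound is needed for the effect), compound 1 gives only a limit, > 100 ug/mL. Compound 2 likewise reaches only the limit, > 100 ug/mL. Compound 3 also sits at the limit, > 100 ug/mL. Compound 3 therefore stands nowhere apart from the others: all three values rest at the limit of > 100 ug/mL in this assay, at which 3 of the 3 values shown sit, and no order among them can be read. Compound 4 `O=C1/C(=C\c2ccccc2Cl)c2ccccc2N1c1c(Cl)cccc1Cl` carries 2-chlorophenyl in place of 4-(dimethylamino)phenyl on a double-bonded chain carbon bound to a double-bonded ring carbon. Among the measured compounds shown here, with every value a limit and no measured step to lean on, the expected step in this assay is a number no higher from compound 3 to compound 4 (the limit leaves the size open), nothing beyond the scatter. Compound 4 is estimated at about 100 ug/mL, within 40 ug/mL to 250 ug/mL, most probably again reported only as a limit.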

Compound 4, concentration for half-maximal effect: 39 ug/mL
Compound 4: the middle estimate sits 2.6-fold (0.41 log units) above what was measured, and the stated range ends above it.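

In this assay, this place on a double-bonded chain carbon bound to a double-bonded ring carbon now proves able to shift the read-out: 2-chlorophenyl in place of 4-(dimethylamino)phenyl gives an at least 2.5-fold lower number from compound 3 to compound 4 (0.40 log units; beyond the scatter). Compound 4 is the only compound shown with a number rather than a limit, so the full size of the step stays open: the limit of > 100 ug/mL in this assay, at which 3 of the 4 values shown sit.

Open, on these data alone, is whether the chlorine's arrival or the dimethylamino group's departure carries the step. A plain phenyl or a 4-chlorophenyl at this place would separate the two.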